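Cytotoxicity notes on the shared core, compounds 1 to 4

The compounds below may be only part of what the source reports. "The series", "measured", "known", "first", "only" and "open" are said of these compounds alone.

Measured so far:
compound 1 `COc1ccc([C@H]2CC(=O)N(C(C)=O)C2)cc1OC1CCCC1`: in a functional assay on HEK293 cells (Homo sapiens) for cytotoxicity (on this read-out higher numbers stand for lower toxicity in this test and lower numbers for higher toxicity in this test), compound 1 gives > 10000 nM, a limit of the assay.
compound 2 `COc1ccc([C@H]2CC(=O)N(C(=O)c3ccccc3)C2)cc1OC1CCCC1`: in this assay compound 2 gives > 10000 nM, a limit.
compound 3 `COc1ccc([C@H]2CC(=O)N(c3cc(N)cc(F)c3)C2)cc1OC1CCCC1`: in this assay compound 3 gives > 10000 nM, a limit.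

Compound 3 therefore stands at the limit in this assay, and all three values shown sit there (the limit of > 10000 nM in this assay, at which 3 of the 3 values shown sit). The steps a step that the two limits leave unreadable from compound 1 to compound 2, a step that the two limits leave unreadable from compound 1 to compound 3 and a step that the two limits leave unreadable from compound 2 to compound 3 are all unreadable, so no size or direction can be taken from them.

Compound 4 `COc1ccc([C@H]2CC(=O)N(c3cccnc3)C2)cc1OC1CCCC1` differs from compound 3 by pyridin-3-yl in place of 3-amino-5-fluorophenyl on an amide-type nitrogen in a ring. The measured steps, all unreadable, give no basis for expecting a change in this assay beyond the scatter. Compound 4 is therefore expected at a step that the limit leaves unreadable from compound 3 to compound 4, most likely again returned as a limit. The estimate for compound 4 in this assay is 15000 nM, in the range 5000 nM to 40000 nM.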

Compound 4, half-maximal cytotoxic concentration: > 10000 nM
Compound 4: only a limit was reported; the forecaster's own chance of this, stated with the estimate: 80%; the middle value does not contradict the limit.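

Compound 4 also gives only a limit in this assay, so no new step can be read among compound 1, compound 2, compound 3 and compound 4: the limit of > 10000 nM in this assay, at which 4 of the 4 values shown sit. The compounds shown leave open whether any group on the amide-type nitrogen in a ring changes this read-out.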